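Changing the amide substituent in a weakly active series

The source may hold more compounds than are shown below. What is called first, only, known or untested is meant among the compounds shown, and "the series" means these compounds.

Of the compounds shown here, three have been measured in a functional assay on BXPC-3 cells (Homo sapiens) for inhibition, read by MTT assay, with a stated time of 7 days; on this read-out lower numbers stand for stronger inhibition and higher numbers for weaker inhibition. Compound 1 `CCOC(=O)[C@@H]1CCC[C@@H](S(=O)(=O)c2ccc(S(=O)(=O)N(CC)CC)cc2)C1` gives 18500 nM. Compound 2 `CCN(CC)S(=O)(=O)c1ccc(S(=O)(=O)N2CCC[C@@H](C(=O)NC3CN(C(=O)C4CC4)C3)C2)cc1`, which carries an amide on its core, gives 18500 nM. Compound 3 `CCOC(=O)[C@@H]1CCCN(S(=O)(=O)c2cccc(S(=O)(=O)N(CC)CC)c2)C1` returns only a limit, > 30000 nM, which marks the edge of what this assay can report rather than a number; the same point is noted as the limit of > 30000 nM in this assay, at which 1 of the 3 values shown sits. On these numbers compound 2 stands level with compound 1, the two values being indistinguishable within the usual scatter, while compound 3 contributes no number at all.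

Compound 4 `CCN(CC)S(=O)(=O)c1ccc(S(=O)(=O)N2CCC[C@@H](C(=O)N[C@H]3CCN(C(=O)OC(C)(C)C)C3)C2)cc1` has not yet been measured. It differs from compound 2 in one place, (1-(tert-butoxycarbonyl)pyrrolidin-3-yl in place of 1-(cyclopropylcarbonyl)azetidin-3-yl on an amide-type nitrogen), so the group on the amide-type nitrogen becomes larger and gains an acceptor, while the rest of the molecule is unchanged. Among the measured compounds shown here, no measured pair in this set shows what such a swap does, so the expectation rests only on where compound 2 sits. The step from compound 2 to compound 4 is expected to be small, a 1.1-fold higher number from compound 2 to compound 4 (0.03 log units; within the scatter), with no clear direction beyond the scatter. Compound 4 is therefore estimated to give about 20000 nM in this assay, most likely between 7000 nM and 45000 nM.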

Compound 4, half-maximal inhibitory concentration: 300 nM
For compound 4 the middle estimate is 67-fold (1.82 log units) above the measured one, outside the stated range (below it).
By their numbers in this assay, from the lowest: compound 4; then compounds 1 and 2 (each within the scatter of the next). At a limit, above all of these: compound 3.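

In this assay, the group on the amide-type nitrogen proves able to move the read-out a long way: 1-(tert-butoxycarbonyl)pyrrolidin-3-yl in place of 1-(cyclopropylcarbonyl)azetidin-3-yl gives a 62-fold lower number from compound 2 to compound 4 (1.79 log units; beyond the scatter) while the rest of the molecule stays the same. The earlier compounds shown here offered no pair differing in one place, so they could not show that any single position mattered; this pair shows that this one does. The swap changes several things at once, since a four-membered ring gives way to a five-membered one, the cyclopropyl ring is lost, a tert-butoxy group arrives and a defined stereocentre enters, and nothing measured here gives a reason for the gain.

Still open, as far as these compounds go, is which of these changes carries the effect: a free amine on the pyrrolidine nitrogen, or a small acetyl group there, would help to separate the tert-butoxycarbonyl group from the ring itself. Also open, from the compounds shown here alone, is whether the mirror-image arrangement at the defined stereocentre would give a similar number.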